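From Ethynyl to Vinyl on a Side Chain

This account rests on a few compounds, and the source may have more. Where it says the series, first, only, none or still open, it means among the compounds named here.

Compound 1 `Cn1c2cnc1OCCCCCCCCOc1ccc(F)cc1-2` gives 73000 nM
Compound 2 `CCCCOc1ncc(-c2ccccc2OC)n1C` gives "not determined" (no result reported)
Compound 3 `C#CCCCCOc1ncc(-c2ccccc2OC)n1C` gives "not determined" (no result reported)

These entries come from a functional assay on U-373MG ATCC cells (Homo sapiens) for inhibition, read by colorimetric assay and MTT assay, with a stated time of 72 h (on this read-out higher numbers stand for weaker inhibition and lower numbers for stronger inhibition), and only compound 1 carries a number there. Compound 3 has no single number, and neither has compound 2, so compound 3 cannot yet be placed on the scale.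

Compound 4 `C=CCCCCOc1ncc(-c2ccccc2OC)n1C` still awaits a measurement. Its structural change from compound 3 is vinyl in place of ethynyl on a saturated chain carbon, four bonds along the chain from an oxygen on an aromatic ring and it amounts to vinyl in place of ethynyl on a saturated chain carbon, four bonds along the chain from an oxygen on an aromatic ring.

Going by the values given here, no measured pair shows what this swap does in this assay and the missing number for compound 3 leaves nothing to start from. With so small a change in the structure, the expectation is a step no larger than the usual scatter, in neither direction. Among the compounds with values here, the only number available as a guide is that of compound 1 at 73000 nM on this scale, where high numbers mean weak inhibition, and this makes for a wide range. For compound 4 the estimated value is 60000 nM with an expected range from 20000 nM to 150000 nM in this test.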

Compound 4, half-maximal inhibitory concentration: 9000 nM
Beside the measured number, compound 4's estimate is 6.7-fold (0.82 log units) above it, and the stated range ends above it.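

No step can be read between compound 3 and compound 4: in this assay compound 4 gives 9000 nM and compound 3 has no single number. From the compounds shown here alone, what vinyl in place of ethynyl does to inhibition on this side chain therefore stays open. No measured evidence bears on this result.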